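The compounds below may be only part of what the source reports. "The series", "measured", "known", "first", "only" and "open" are said of these compounds alone.

Compound 1 `COc1cc2c(Oc3ccc(NC(=O)c4nn(-c5ccccc5C)cc(C)c4=O)c(F)c3)ccnc2cc1OCCCCCCC(=O)NO` and compound 3 `COc1cc2c(Oc3ccc(NC(=O)c4nn(-c5ccccc5C)cc(C)c4=O)cc3F)ccnc2cc1OCCCC(=O)NO` share much of their framework, but the difference between the two cores is not broken down here. In a functional assay on MCF7 cells (Homo sapiens) for inhibition, read by MTT assay, with a stated time of 72 h (a lower number here means a stronger inhibitor, a higher number a weaker inhibitor), compound 1 gives 2690 nM, and compound 3 gives 2600 nM; these two numbers sit within the scatter of each other, so nothing separates them. Compound 2 `COc1cc2c(Oc3ccc(NC(=O)c4nn(-c5ccccc5C)ccc4=O)cc3F)ccnc2cc1OCCCC(=O)NO` is derived from compound 3 by a single change, (hydrogen in place of methyl on an aromatic carbon). In this assay compound 2 gives 3200 nM, which is a 1.2-fold higher number from compound 3 to compound 2 (0.09 log units; within the scatter), a step that does not rise above the noise of the measurement.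

Compound 4 `COc1cc2c(Oc3ccc(NC(=O)c4nn(-c5ccccc5C)ccc4=O)c(F)c3)ccnc2cc1OCCCCCCC(=O)NO` has not yet been measured. It stands to compound 1 exactly as compound 2 stands to compound 3: the change is hydrogen in place of methyl on an aromatic carbon, and the surroundings of the altered position are the same, word for word, in both pairs. Within the data shown here, the only guide available is therefore the step from compound 3 to compound 2. On that basis the account expects compound 4 to show a step of a 1.2-fold higher number from compound 1 to compound 4 (0.06 log units; within the scatter) relative to compound 1, an estimate resting on the fact that compound 2 gave 3200 nM after the same change was applied to compound 3. With one precedent, and that one within the scatter, the expectation is simply that compound 4 lands close to compound 1. The estimate for compound 4 in this assay is 3100 nM, with a plausible range from 1500 nM to 6500 nM.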

Compound 4, half-maximal inhibitory concentration: 3650 nM
For compound 4 the middle estimate is 1.2-fold (0.07 log units) below the measured one; low and high end bracket the measured number.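

In this assay, hydrogen in place of methyl on the core of compound 1 gives a 1.4-fold higher number from compound 1 to compound 4 (0.13 log units; within the scatter), so this step, like the earlier one, does not rise above the noise of the measurement. Set side by side, the two steps do not differ: the same change on two cores in this assay, a 1.2-fold higher number (0.09 log units; within the scatter) from compound 3 to compound 2 and a 1.4-fold higher number (0.13 log units; within the scatter) from compound 1 to compound 4, 1.1-fold (0.04 log units) apart, within the scatter of two such steps. This shows that the change carries over between these two cores in the sense that it gives no readable step on either of them, but it does not show a real effect of the methyl group of any size or direction, and two pairs say nothing about other cores or other assays.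

The compounds shown leave open whether anything other than methyl or hydrogen at this position, such as an ethyl group, a chlorine atom or a methoxy group, would give a step beyond the scatter on either core. They also leave open whether the methyl-to-hydrogen change would stay as small if the chain end were altered, for example with a carboxylic acid or an amine in place of the group that ends the chain in all four compounds.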